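Swapping a carbamoyl for a dihydroxyethyl side chain

This account rests on a few compounds, and the source may have more. Where it says the series, first, only, none or still open, it means among the compounds named here.

Of the compounds shown here, three sharing the same core have been measured in an assay for inhibition of RAC-alpha serine/threonine-protein kinase (Homo sapiens), read by HTRF, with a stated time of 1 h; on this read-out higher numbers stand for weaker inhibition and lower numbers for stronger inhibition. Compound 1 `Cn1ncc(Cl)c1-c1cc(C(=O)N[C@@H]2CNCC[C@H]2c2ccc(C(F)(F)F)cc2)oc1Cl` gives 9.3 nM. Compound 2 `CC(=O)NCC[C@@H]1C[C@@H](c2ccc(F)c(F)c2)[C@H](NC(=O)c2cc(-c3c(Cl)cnn3C)c(Cl)o2)CN1` gives 2.49 nM. Compound 3 `Cn1ncc(Cl)c1-c1cc(C(=O)N[C@@H]2CN[C@H](CC(N)=O)C[C@H]2c2ccc(Cl)c(Cl)c2)oc1Cl` gives 3.24 nM, the second highest of the three numbers; compound 2 sits within the usual scatter of it, while compound 1 lies beyond the scatter on the higher side. Compound 4 `Cn1ncc(Cl)c1-c1cc(C(=O)N[C@@H]2CN[C@H](CC(O)CO)C[C@H]2c2ccc(Cl)c(Cl)c2)oc1Cl` has not been measured. It differs from compound 3 in one place: 1,2-dihydroxyethyl in place of carbamoyl on a saturated chain carbon bound to a saturated ring carbon. The side chain keeps its hydrogen-bond donors and acceptors and grows by one heavy atom, so the step is expected to be small, with no clear direction beyond the scatter, as a 1.4-fold higher number from compound 3 to compound 4 (0.14 log units; within the scatter). Compound 4 is therefore estimated at 4.5 nM, within 1.5 nM to 14 nM.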

Compound 4, half-maximal inhibitory concentration: 3.79 nM
Compound 4: middle estimate off by 1.2-fold (0.07 log units), on the high side, within the range that was stated.
By their numbers in this assay, from the lowest: compounds 2, 3 and 4 (each within the scatter of the next); then compound 1.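

In this assay the change from carbamoyl to 1,2-dihydroxyethyl on a saturated chain carbon bound to a saturated ring carbon amounts to a 1.2-fold higher number from compound 3 to compound 4 (0.07 log units; within the scatter) and so leaves the reading unmoved. For this one pair, the carbamoyl group is not needed to keep the number in the same range, since 1,2-dihydroxyethyl carries no nitrogen at all. No measurement available here says why the two groups read alike. From the compounds shown here alone, whether an amine, a carboxylic acid or a longer chain at this place would also keep the number there remains open.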